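Furan aldehyde in place of isoxazole at the chain end

The source may hold more compounds than are shown below. What is called first, only, known or untested is meant among the compounds shown, and "the series" means these compounds.

Measured compounds:
compound 1 `Cc1cc(CCCCCOc2c(Cl)cc(C3=NCCO3)cc2Cl)on1`, in a physicochemical assay for lipophilicity, read by HPLC (on this read-out higher numbers stand for higher lipophilicity and lower numbers for lower lipophilicity), compound 1 gives 4.6.
compound 2 `Cc1cc(CCCCCOc2c(C)cc(-c3nnn(C)n3)cc2C)on1`, in this assay compound 2 gives 3.6.

Within the data shown here, compound 2 holds the lower of the two numbers; the only comparison, compound 1, stands higher by a margin beyond the usual scatter. Among the measured compounds shown here, no direct step between measured compounds is available. Compound 3 `Cc1cc(-c2nnn(C)n2)cc(C)c1OCCCCCc1ccc(C=O)o1` differs from compound 2 as follows: 5-formylfuran-2-yl in place of 3-methyl-1,2-oxazol-5-yl on a saturated chain carbon, five bonds along the chain from an oxygen on an aromatic ring. For the measured compounds named here, with no measured step of this kind to lean on, the expected change in this assay is small, if any, and none beyond the scatter; the estimated step is a number 0.10 log units lower from compound 2 to compound 3 (within the scatter). For compound 3 the estimate is 3.5, with a range from 3 to 4.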

Compound 3, partition coefficient: 3.5
Beside the measured number, compound 3's estimate shows no gap at the digits printed; the range from low to high includes it.
By their numbers in this assay, from the lowest: compounds 3 and 2 (each within the scatter of the next); then compound 1.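

In this assay, 5-formylfuran-2-yl in place of 3-methyl-1,2-oxazol-5-yl on a saturated chain carbon, five bonds along the chain from an oxygen on an aromatic ring, gives a number 0.10 log units lower from compound 2 to compound 3 (within the scatter). Compound 1 and compound 2 both carry 3-methyl-1,2-oxazol-5-yl here, so they could not show how this place responds to another group. This exchange of one five-membered aromatic ring for another leaves the read-out within the scatter.

As far as these compounds go, whether an amine or a carboxylic acid in this place would also stay within the scatter remains open. Nothing given here explains the result.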